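The compounds below may be only part of what the source reports. "The series", "measured", "known", "first", "only" and "open" are said of these compounds alone.

Measured compounds:
- compound 1, `O=c1c(-c2ccc(O)cc2)coc2cc(OCCCCBr)ccc12`: in a functional assay on mitochondria (Cricetulus griseus) for inhibition of Monoamine oxidase (Homo sapiens), tested at 3 uM (a higher number here means a stronger effect of the compound at the concentration tested, a lower number a weaker effect), compound 1 gives 84.7%
- compound 2, `O=c1c(-c2ccc(O)cc2)coc2cc(OCCC3OCCCO3)ccc12`: in this assay compound 2 gives 75.3%
- compound 3, `O=C(O)CCCCCCCCCOc1ccc2c(=O)c(-c3ccc(O)cc3)coc2c1`: in this assay compound 3 gives 89.6%

All three share one core and differ only in the chain attached to an oxygen on an aromatic ring. Compound 1 sits second highest of the three numbers, but both of its neighbours lie within the usual scatter: the step of a number 4.9 percentage points higher from compound 1 to compound 3 (within the scatter) and the step of a number 9.4 percentage points lower from compound 1 to compound 2 (within the scatter) are each too small to count as a real difference. For the measured compounds named here, only the step of a number 14.3 percentage points higher from compound 2 to compound 3 (beyond the scatter) reaches beyond the scatter, and it is a modest one.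

Compound 4, `O=C(O)CCCCCCOc1ccc2c(=O)c(-c3ccc(O)cc3)coc2c1`, is not yet measured. It differs from compound 1 by 2-carboxyethyl in place of bromo on a saturated chain carbon, four bonds along the chain from an oxygen on an aromatic ring. The most telling comparison is the step of a number 4.9 percentage points higher from compound 1 to compound 3 (within the scatter), which places a longer acid chain at the same spot and changes little. Compound 4 carries a shorter acid chain at that spot, so a similarly small move is expected. For compound 4 the expected step is a number 1.3 percentage points higher from compound 1 to compound 4 (within the scatter), which is within the scatter. Compound 4 is therefore estimated at 86%, with a range from 74% to 96%.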

Compound 4, a percentage reported as inhibition, at one concentration (the size of the read-out at that concentration, not a potency): 87.4%
The estimate for compound 4 lay 1.4 percentage points below the measured number; the measured number falls inside the stated range.
By their numbers in this assay, from the lowest: compounds 2, 1, 4 and 3 (each within the scatter of the next, the first and the last beyond it).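

In this assay, the change from bromo to 2-carboxyethyl gives a number 2.7 percentage points higher from compound 1 to compound 4 (within the scatter), and the change from 3-carboxypropyl to carboxy at the end of the chain gives a number 2.2 percentage points lower from compound 3 to compound 4 (within the scatter), so the bromo chain and the two acid chains of different length cannot be told apart here. The new acid also gives a number 12.1 percentage points higher from compound 2 to compound 4 (beyond the scatter), which means that compound 3 and compound 4 both stand clear of the chain with the six-membered ring in compound 2, while the bromo chain of compound 1 does not. Nothing available explains why these different chain ends read so much alike.

On these data alone, it remains open whether an amine or a methyl ester at the chain end would read like the carboxylic acid, and whether an acid on a much shorter chain would hold up as well. Each number is also a read-out at a single concentration, so it shows only the size of the effect at that concentration, and whether compound 1, compound 3 and compound 4 would give a stronger or weaker effect than one another at other concentrations stays hidden.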